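Replacing a (Furan-2-yl)carbonyl with a (4-Bromophenyl)sulfonyl

The source may report more compounds than this note shows. Statements on the series, on what has been measured and on what is new or still open speak of the compounds shown alone.

In a functional assay on A549 cells (Homo sapiens) for antiproliferative activity, read by MTT assay, with a stated time of 72 h (on this read-out lower numbers stand for stronger inhibition and higher numbers for weaker inhibition), compound 1 `CC(=O)N(C)c1ccc2[nH]c(-c3n[nH]c4ccccc34)cc2n1` gives only a limit, > 50000 nM.
In this assay compound 2 `CN(C(=O)c1ccco1)c1ccc2[nH]c(-c3n[nH]c4ccccc34)cc2n1` gives 15500 nM.

For the measured compounds named here, compound 2 is the only compound with a measured number; compound 1 reached only a limit (the limit of > 50000 nM in this assay, at which 1 of the 2 values shown sits). Going by the values given here, the one measured step, an at least 3.2-fold lower number from compound 1 to compound 2 (0.50 log units; beyond the scatter), shows that enlarging the group on the carbonyl carbon helped. Compound 3 `CN(c1ccc2[nH]c(-c3n[nH]c4ccccc34)cc2n1)S(=O)(=O)c1ccc(Br)cc1` carries a different change at the same nitrogen: (4-bromophenyl)sulfonyl in place of (furan-2-yl)carbonyl on a nitrogen on an aromatic ring. That earlier step bears on it only loosely, since here the carbonyl itself is exchanged, so a step of a 1.6-fold lower number from compound 2 to compound 3 (0.19 log units; within the scatter) is expected, near the scatter. Compound 3 is estimated at 10000 nM, between 3000 nM and 50000 nM.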

Compound 3, half-maximal inhibitory concentration: 19700 nM
For compound 3 the middle estimate is 2.0-fold (0.29 log units) below the measured one; low and high end bracket the measured number.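

In this assay, a 1.3-fold higher number from compound 2 to compound 3 (0.10 log units; within the scatter) means that (4-bromophenyl)sulfonyl and (furan-2-yl)carbonyl cannot be told apart at this nitrogen, even though the linking group and the ring both change. Compared with acetyl, the result is an at least 2.5-fold lower number from compound 1 to compound 3 (0.40 log units; beyond the scatter), and this step rests on a limit: the limit of > 50000 nM in this assay, at which 1 of the 3 values shown sits.

Still open, on these data alone, is whether the ring or the sulfonyl link accounts for the difference from acetyl, which a methylsulfonyl group on the same nitrogen would help to separate. Also open, as far as these compounds go, is what an amine or a carboxylic acid in place of the bromine would do.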